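The source may report more compounds than this note shows. Statements on the series, on what has been measured and on what is new or still open speak of the compounds shown alone.

Measured compounds:
Compound 1, `CCCCc1nc(=O)c(S(=O)(=O)c2ccc(-c3ccc(F)nc3)cc2)c(O)n1-c1c(OC)cccc1OC`: 69%
Compound 2, `CCCCc1nc(=O)c(S(=O)(=O)c2ccc(-n3cc(Cl)ccc3=O)cc2)c(O)n1-c1c(OC)cccc1OC`: 100%
Compound 3, `COc1cccc(OC)c1-n1c(CCC(C)C)nc(=O)c(S(=O)(=O)c2ccc(-c3ccc(F)nc3)cc2)c1O`: 31%

In an ADME assay on microsomes from liver (Mus musculus) for metabolic stability, using NADPH, with a stated time of 10 min (on this read-out lower numbers stand for a less stable compound and higher numbers for a more stable compound), compound 3 stands lowest of the three, with compound 1 well above it and compound 2 higher still. Compound 4, `COc1cccc(OC)c1-n1c(COC(C)C)nc(=O)c(S(=O)(=O)c2ccc(-c3ccc(F)nc3)cc2)c1O`, differs from compound 3 by isopropoxy in place of isobutyl on a saturated chain carbon bound to an aromatic carbon. Going by the values given here, the one measured step that touches this chain is a number 38 percentage points lower from compound 1 to compound 3 (beyond the scatter), a large drop. The step of a number 31 percentage points higher from compound 1 to compound 2 (beyond the scatter) concerns the other end of the molecule and bears only loosely on this change. Among the compounds with values here, no measured pair shows an oxygen entering the chain, so the direction remains uncertain, and a modest rise is expected, a number 19 percentage points higher from compound 3 to compound 4 (beyond the scatter). Compound 4 is therefore estimated at 50%, within a range from 25% to 80%.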

Compound 4, percent of the compound remaining: 90%
Beside the measured number, compound 4's estimate is 40 percentage points below it; measured number above the stated range.
By their numbers in this assay, from the lowest: compound 3; then compound 1; then compounds 4 and 2 (each within the scatter of the next).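

Putting isopropoxy in place of isobutyl on this saturated chain carbon gives a number 59 percentage points higher from compound 3 to compound 4 (beyond the scatter). The change also compares well with the unbranched butyl chain of the core, with isopropoxy in place of propyl giving a number 21 percentage points higher from compound 1 to compound 4 (beyond the scatter), so at this position the isopropoxy group does more than recover the loss seen with isobutyl. Nothing measured here explains why this chain gives the higher number.

From the compounds shown here alone, whether a straight ethoxy chain or an amine at the same place would give a similar number stays open. So does whether isopropoxy would behave alike on the core of compound 2.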